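The compounds below may be only part of what the source reports. "The series", "measured", "known", "first", "only" and "open" are said of these compounds alone.

Compound 1, `COc1cc(N)c(Cl)cc1C(=O)NC1CCNCC1`, is the simplest member of the pair measured in a functional assay on HEK293 cells for activation of 5-hydroxytryptamine receptor 4 (Homo sapiens), read by cAMP accumulation; on this read-out lower numbers stand for smaller maximal responses and higher numbers for larger maximal responses. In that assay compound 1 reaches > 100%, which is a limit of the assay and not a number. Compound 2, `CCCCCN1CCC(NC(=O)c2cc(Cl)c(N)cc2OC)CC1`, bears pentyl in place of hydrogen on an amine nitrogen in a ring. In this assay compound 2 gives > 100%, again a limit of the assay rather than a number. The step that the two limits leave unreadable from compound 1 to compound 2 cannot be read because of the limit of > 100% in this assay, at which 2 of the 2 values shown sit. Compound 3, `COc1cc(N)c(Cl)cc1C(=O)NC1CCN(CCN2CCN(S(C)(=O)=O)CC2)CC1`, differs from compound 2 by 4-(methylsulfonyl)piperazin-1-yl in place of propyl on a saturated chain carbon, two bonds along the chain from an amine nitrogen in a ring. Among the compounds with values here, no measured step bears on this change, since the only step known is unreadable, so the data offer no direction for the change. Compound 3 is therefore expected to sit near 105%, within 90% to 120%. The step that the limit leaves unreadable from compound 2 to compound 3 is expected to be none beyond the scatter.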

Compound 3, intrinsic activity: the largest response reached, in percent of the reference agonist's: 97%
Beside the measured number, compound 3's estimate is 8 percentage points above it, within the range that was stated.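

In this assay, within the data shown here, compound 3 gives 97%, the first value here that is a number and not a limit of the assay. The place on a saturated chain carbon, two bonds along the chain from an amine nitrogen in a ring, therefore now has a measured response with 4-(methylsulfonyl)piperazin-1-yl on it, and the change to this group from propyl gives a number at least 3 percentage points lower from compound 2 to compound 3 (that floor lies within the scatter), so no loss beyond the scatter is established. The true size of this step cannot be read because compound 2 stands at a limit of the assay: the limit of > 100% in this assay, at which 2 of the 3 values shown sit.

On these data alone, it remains open whether the piperazine ring or the methylsulfonyl group shapes this response, which an unsubstituted piperazine could separate. As far as these compounds go, how a morpholine or a carboxylic acid at this place would read in this assay also stays open.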